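Swapping the terminal amine ring of a kinase-type scaffold

The compounds below may be only part of what the source reports. "The series", "measured", "known", "first", "only" and "open" are said of these compounds alone.

The two measured compounds share one core and differ only in the saturated ring at the end of the propyl chain. Compound 1 `COc1cc2c(Oc3ccc(NC(=O)c4nnn(-c5ccccc5C(F)(F)F)c4C)cc3F)ccnc2cc1OCCCN1CCCC1` carries a pyrrolidin-1-yl there, and in a functional assay on U-87MG ATCC cells (Homo sapiens) for cytotoxicity, read by MTT assay, with a stated time of 72 h (a lower number here means a stronger inhibitor, a higher number a weaker inhibitor), compound 1 gives 1060 nM. Compound 2 `COc1cc2c(Oc3ccc(NC(=O)c4nnn(-c5ccccc5C(F)(F)F)c4C)cc3F)ccnc2cc1OCCCN1CCCCC1` carries a piperidin-1-yl in the same place, and in this assay compound 2 gives 1150 nM. Compound 2 has the highest of the two numbers, but the step of a 1.1-fold higher number from compound 1 to compound 2 (0.04 log units; within the scatter) is within the scatter, so the two cannot be told apart on these data.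

Compound 3 `COc1cc2c(Oc3ccc(NC(=O)c4nnn(-c5ccccc5C(F)(F)F)c4C)cc3F)ccnc2cc1OCCCN1CCN(C)CC1` is the next member: 4-methylpiperazin-1-yl in place of piperidin-1-yl on a saturated chain carbon, three bonds along the chain from an oxygen on an aromatic ring. Among the measured compounds shown here, the only measured step that bears on it is the ring change from compound 1 to compound 2, which was within the scatter; no measured pair shows the effect of a second ring nitrogen with its methyl. The expectation is therefore a step of no more than the scatter in this assay, with no firm direction, expressed as a 1.0-fold lower number from compound 2 to compound 3 (0.02 log units; within the scatter). Compound 3 is estimated at 1100 nM, with a range from 450 nM to 2700 nM.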

Compound 3, half-maximal inhibitory concentration: 1420 nM
Compound 3: the middle estimate sits 1.3-fold (0.11 log units) below what was measured; the range from low to high includes it.
By their numbers in this assay, from the lowest: compounds 1, 2 and 3 (each within the scatter of the next).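

In this assay, replacing the ring at this position on a saturated chain carbon, three bonds along the chain from an oxygen on an aromatic ring, with 4-methylpiperazin-1-yl gives a 1.2-fold higher number from compound 2 to compound 3 (0.09 log units; within the scatter) and, measured against the pyrrolidin-1-yl ring, a 1.3-fold higher number from compound 1 to compound 3 (0.13 log units; within the scatter) as well. Among the compounds shown here, the earlier pair compared only two rings with a single hetero atom, whereas this result shows that a ring with a second nitrogen carrying a methyl also cannot be told apart from either of them, so all three terminal rings lie within the scatter of one another. No independent measurement is available to account for this absence of a readable difference.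

Still open, on these data alone, is whether any terminal group at the end of the propyl chain can shift the number beyond the scatter, for example a morpholin-4-yl ring, a piperazin-1-yl ring without the methyl, or an open-chain dimethylamino group. The compounds shown also leave open what happens when the propyl chain itself gives way to a shorter ethyl chain or a longer butyl chain.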